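Aryl swap on the ring nitrogen: trifluoromethyl to difluoro

A few compounds are considered here, and "the series" means these few. Any claim that something is new, unique, unknown or untested is made for them only; others in the source may bear on it.

Working notes on the series. Among the measured compounds shown here, compound 1 `Nc1scc(CN2CCN(c3cccc(C(F)(F)F)c3)CC2)c1C(=O)c1ccc(Cl)cc1` gives -80% in a functional assay on CHO cells with adenosine receptor A1 (Homo sapiens) as the target, read by cAMP accumulation and immunoassay, with a stated time of 6 min, tested at 10 uM (a higher number here means a weaker effect of the compound at the concentration tested, a lower number a stronger effect), the lowest of the three numbers measured so far. Compound 2 `Nc1scc(CN2CCC(c3ccc(Cl)cc3)CC2)c1C(=O)c1ccc(Cl)cc1` stands nearest, giving -61% in this assay, a gap beyond the scatter. Compound 3 `Nc1scc(CN2CCN(c3c(F)cccc3F)CC2)c1C(=O)c1cccc(C(F)(F)F)c1` lies furthest, giving 4% in this assay. For the measured compounds named here, no two measured compounds differ in a single place, so no step size is known directly. Compound 4 `Nc1scc(CN2CCN(c3cc(F)cc(F)c3)CC2)c1C(=O)c1ccc(Cl)cc1` differs from compound 1 by one change: 3,5-difluorophenyl in place of 3-(trifluoromethyl)phenyl on an amine nitrogen in a ring. The rest of compound 1 is kept. The change is expected to move the number upward, toward a weaker effect, by a number 25 percentage points higher from compound 1 to compound 4 (beyond the scatter), a step beyond the scatter. Compound 4 is estimated at -55% in this assay, with a range from -90% to -10%.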

Compound 4, a percentage reported as activity, at one concentration (the size of the read-out at that concentration, not a potency): -79%
For compound 4 the middle estimate is 24 percentage points above the measured one; low and high end bracket the measured number.
By their numbers in this assay, from the lowest: compounds 1 and 4 (each within the scatter of the next); then compound 2; then compound 3.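

In this assay, among the compounds shown here, the first single-place step reads a number 1 percentage points higher from compound 1 to compound 4 (within the scatter) and so gives the first direct look at this position. On an amine nitrogen in a ring, 3,5-difluorophenyl can stand in place of 3-(trifluoromethyl)phenyl with the rest of compound 1 kept and no change that can be told from the scatter. Nothing on hand offers a reason for this result. Still open, from the compounds shown here alone, is whether this position accepts an aryl group bearing a nitrile, a carboxylic acid or an amine. Going by these compounds, a plain alkyl chain in place of the aryl group is equally open.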